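The source may hold more compounds than are shown below. What is called first, only, known or untested is meant among the compounds shown, and "the series" means these compounds.

Working notes on the aryloxyacetamide series. All three measured compounds share the same core and differ only in the group on the amide-type nitrogen. In an assay on HEK293 cells for agonist activity at transient receptor potential cation channel subfamily M member 8 (Homo sapiens), read by fluorescence and calcium flux, with a stated time of 15 min (a lower number here means that less compound is needed, a higher number that more compound is needed for the effect), compound 1 `Cc1ccc(OCC(=O)N(Cc2cccs2)CC(C)C)cc1` gives 900 nM. Compound 2 `Cc1ccc(OCC(=O)N(Cc2cccs2)c2nccn2C)cc1` gives 1790 nM in this assay; the change a 2.0-fold higher number from compound 1 to compound 2 (0.30 log units; within the scatter) stays within the scatter. Compound 3 `COCCN(Cc1cccs1)C(=O)COc1ccc(C)cc1` gives 400 nM, the lowest of the three numbers; the steps of a 2.3-fold lower number from compound 1 to compound 3 (0.35 log units; beyond the scatter) and a 4.5-fold lower number from compound 2 to compound 3 (0.65 log units; beyond the scatter) are both modest but beyond the scatter, so compound 3 stands apart from compound 1 and compound 2 on this read-out.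

Compound 4 `Cc1ccc(OCC(=O)N(O)Cc2cccs2)cc1` has not yet been measured. Relative to compound 3 the change is hydroxy in place of 2-methoxyethyl on an amide-type nitrogen: the 2-methoxyethyl leaves, a hydroxy enters, on an amide-type nitrogen whose other neighbours are the carbonyl carbon and a saturated chain carbon. Among the compounds with values here, no measured step has a hydroxy at this position; the nearest precedents are the three steps above, which all alter the same nitrogen substituent and move this assay only modestly. Since compound 3 holds the lowest number, the removal of its 2-methoxyethyl is expected to give a modest rise rather than a fall: compound 4 is estimated at 1000 nM, with the step of a 2.5-fold higher number from compound 3 to compound 4 (0.40 log units; beyond the scatter) expected, and a range from 300 nM to 4000 nM.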

Compound 4, half-maximal effective concentration: 8000 nM
Estimate against measurement, compound 4: 8.0-fold (0.90 log units) below, outside the stated range (above it).
By their numbers in this assay, from the lowest: compound 3; then compounds 1 and 2 (each within the scatter of the next); then compound 4.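

In this assay the group on the amide-type nitrogen proves less forgiving than the earlier compounds suggested: hydroxy in place of 2-methoxyethyl gives a 20-fold higher number from compound 3 to compound 4 (1.30 log units; beyond the scatter) and is the only large step among those shown, whereas the earlier steps at this nitrogen were modest or within the scatter. The rise does not depend on which group serves as the reference, with a 4.5-fold higher number from compound 2 to compound 4 (0.65 log units; beyond the scatter) against the 1-methyl-1H-imidazol-2-yl group and an 8.9-fold higher number from compound 1 to compound 4 (0.95 log units; beyond the scatter) against the isobutyl group, so the hydroxy compound holds the highest number of the four despite the differences among the other three groups. No measurement shown explains this rise.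

The hydroxy differs from 2-methoxyethyl both in heavy atoms and in bringing a hydrogen-bond donor, so the compounds shown leave open which of these changes goes with the higher number; a methoxy or a 2-hydroxyethyl group on the same nitrogen would help to separate them. Also open, as far as these compounds go, is whether a longer ether chain, such as 3-methoxypropyl, would keep or lower the number held by compound 3 at 400 nM in this assay.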